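This account rests on a few compounds, and the source may have more. Where it says the series, first, only, none or still open, it means among the compounds named here.

Of the compounds shown here, two have been measured in a functional assay on PC-3 cells (Homo sapiens) for inhibition, read by sulforhodamine B assay; on this read-out higher numbers stand for weaker inhibition of growth and lower numbers for stronger inhibition of growth. Compound 1 `O=C(CCC1=CCN(Cc2ccc(F)cc2)C1=O)NO` gives 5310 nM, and compound 2 `Cc1ccc(CCCCN2CC=C(CCC(=O)NO)C2=O)cc1` gives 6090 nM. Compound 2 has the higher of the two numbers, yet the two values lie within the scatter of each other, so nothing separates them.

Compound 3 `O=C(CCC1=CCN(CCCCc2ccc(Cl)cc2)C1=O)NO` has not yet been measured in this assay. It differs from compound 2 in one place: chloro in place of methyl on an aromatic carbon. The chloro takes the spot on an aromatic carbon of a six-membered aromatic ring of carbon only, para to a large group, that the methyl held before.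

No measured step of this kind exists among the shown compounds, so the outcome rests on the change alone: one heavy atom replaced by one heavy atom, with no ring, donor, acceptor or charge gained or lost. Such a swap is expected to move the number little, and the estimated step is a 1.1-fold lower number from compound 2 to compound 3 (0.04 log units; within the scatter), not beyond the scatter. Compound 3 is therefore expected to give about 5500 nM, within a range from 2500 nM to 12000 nM.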

Compound 3, concentration for 50% growth inhibition: 6090 nM
Estimate against measurement, compound 3: 1.1-fold (0.04 log units) below; the measured number falls inside the stated range.
By their numbers in this assay, from the lowest: compounds 1, 2 and 3 (each within the scatter of the next).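

In this assay, for the compounds shown here, the change from 4-methylphenyl to 4-chlorophenyl, with chloro in place of methyl on an aromatic carbon para to a large group, gives no change at the digits printed from compound 2 to compound 3 (within the scatter) as the only step so far between compounds that differ in one place. It shows that, for this pair, this swap of one heavy atom for another leaves the growth-inhibition read-out within the usual scatter, something compounds 1 and 2 alone could not show. No further data bear on this result, so it stands without an explanation.

From the compounds shown here alone, whether an amine or a carboxylic acid at the same aromatic carbon would give a number beyond the scatter remains open. Also open, going by these compounds, is what a longer chain between the aromatic ring and the shared core would do in this assay here.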